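Cytotoxicity notes on a benzimidazole-aryl series: compound 3 to compound 4

The compounds below may be only part of what the source reports. "The series", "measured", "known", "first", "only" and "open" are said of these compounds alone.

Compound 1 `COc1ccc(-c2nc3cc(Cl)c(Cl)cc3[nH]2)cc1` and compound 2 `CN1CCN(CC(=O)Nc2ccc(-c3nc4cc(Cl)c(Cl)cc4[nH]3)cc2)CC1` carry the dichloro core, and in an ADME assay on BHK cells (Mesocricetus auratus) for cytotoxicity, read by MTT assay, with a stated time of 96 h (on this read-out lower numbers stand for higher toxicity in this test and higher numbers for lower toxicity in this test), compound 1 gives 18000 nM while compound 2 gives 41000 nM. Compound 3 `Cn1c(-c2ccc([N+](=O)[O-])cc2)nc2cc(C(F)(F)F)ccc21` carries the trifluoromethyl core with a methyl on the ring nitrogen. For compound 3 in this assay only a limit is recorded, > 100000 nM; this is the limit of > 100000 nM in this assay, at which 1 of the 3 values shown sits, so compound 3 stands at the least toxic end of the numbers shown, with no exact value.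

Compound 4 `Cn1c(-c2ccc(NC(=O)CN3CCCC3)cc2)nc2cc(C(F)(F)F)ccc21` is not yet measured. It differs from compound 3 in one place: (((pyrrolidin-1-yl)methyl)carbonyl)amino in place of nitro on an aromatic carbon. For the measured compounds named here, no pair of measured compounds differing in one place is available, so the size of this step is not known from the series.

The step from compound 3 to compound 4 in this assay is expected to be an at least 1.2-fold lower number from compound 3 to compound 4 (0.09 log units; that floor lies within the scatter), small or none beyond the scatter, with any movement toward lower numbers. Compound 4 is estimated at 80000 nM, between 30000 nM and 250000 nM.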

Compound 4, half-maximal cytotoxic concentration: 27000 nM
Beside the measured number, compound 4's estimate is 3.0-fold (0.47 log units) above it, outside the stated range (below it).
By their numbers in this assay, from the lowest: compounds 1, 4 and 2 (each within the scatter of the next, the first and the last beyond it). At a limit, above all of these: compound 3.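

In this assay, for the compounds shown here, placing (((pyrrolidin-1-yl)methyl)carbonyl)amino in place of nitro on an aromatic carbon gives an at least 3.7-fold lower number from compound 3 to compound 4 (0.56 log units; beyond the scatter), the first step between compounds differing in one place that can be read. The change at this position, para to a large group, therefore registers on this read-out, and it moves toward higher toxicity in this test. The size of the step remains only a floor, because compound 3 has a limit of the assay and no exact value: the limit of > 100000 nM in this assay, at which 1 of the 4 values shown sits.

These compounds do not separate the loss of nitro from the arrival of the pyrrolidine-bearing chain. Going by these compounds, how a simple amine or a carboxylic acid on the same aromatic carbon would read, and whether the same exchange carries over to the core of compound 1, remains open.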